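This account rests on a few compounds, and the source may have more. Where it says the series, first, only, none or still open, it means among the compounds named here.

Compound 3 `CC(C(=O)N1CCN(c2cccc(F)c2)CC1)N1C(=O)CCC1=O` is the starting point of this step. In a functional assay on the whole organism (strain Swiss) with Mus musculus as the target, in the maximal electroshock model, with a stated time of 0.5 h, at a dose of 100 mg/kg by the intraperitoneal route (a higher number here means a stronger effect of the compound at the dose given, a lower number a weaker effect), compound 3 gives 0%. Its two measured relatives sit at the same level: compound 1 `COc1cccc(N2CCN(C(=O)C(C)N3C(=O)CCC3=O)CC2)c1` gives 0% in this assay, and compound 2 `CC(C(=O)N1CCN(c2ccccc2)CC1)N1C(=O)CCC1=O` gives 0%. Accordingly, the three steps among them are flat: no change at the digits printed from compound 1 to compound 2 (within the scatter), no change at the digits printed from compound 1 to compound 3 (within the scatter) and no change at the digits printed from compound 2 to compound 3 (within the scatter). Within this small set, swapping the group on the aromatic carbon has so far made no difference that rises above the scatter.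

Compound 4 `CC(C(=O)N1CCN(c2cccc(C(F)(F)F)c2)CC1)N1C(=O)CCC1=O` differs from compound 3 in one place: trifluoromethyl in place of fluoro on an aromatic carbon. The steps that bear on this are the three above, each of them without change at the digits shown, and all three concern the same aromatic carbon. They give no sign that a change at that position moves the read-out of this assay, though a trifluoromethyl group has not yet been tried here, so the expectation rests on three flat steps only. He therefore expects a step of no change at the digits printed from compound 3 to compound 4 (within the scatter), that is none beyond the scatter. For compound 4 the estimate in this assay is 0%, with a range from 0% to 15%.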

Compound 4, a percentage reported as activity, at one dose (the size of the read-out at that dose, not a potency): 75%
The estimate for compound 4 lay 75 percentage points below the measured number, and the stated range ends below it.
By their numbers in this assay, from the lowest: compounds 1, 2 and 3 (each within the scatter of the next); then compound 4.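

In this assay the aromatic carbon that had looked silent proves able to move the read-out: trifluoromethyl in place of fluoro gives a number 75 percentage points higher from compound 3 to compound 4 (beyond the scatter) and trifluoromethyl in place of hydrogen gives a number 75 percentage points higher from compound 2 to compound 4 (beyond the scatter) and trifluoromethyl in place of methoxy gives a number 75 percentage points higher from compound 1 to compound 4 (beyond the scatter) and so the flat steps among the first three compounds reflected those particular groups and not an indifferent position. Fluorine as such is not enough, since compound 3 carries a single fluoro group on this carbon and stays level with compound 2, whereas only the larger trifluoromethyl group, with its four heavy atoms, separates compound 4 from the rest. The data at hand offer nothing that explains why this one group stands apart from hydrogen, fluoro and methoxy.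

The compounds shown leave open whether the gain belongs to trifluoromethyl alone or would also appear with a chloro group, a nitrile or a longer fluorinated chain such as pentafluoroethyl on the same carbon. They also leave open whether trifluoromethyl would do the same on another carbon of the ring, and how potent compound 4 is, as its read-out is the size of an effect at one dose.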